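Adding an Amino Group to Compound 2: an Expected Step

A few compounds are considered here, and "the series" means these few. Any claim that something is new, unique, unknown or untested is made for them only; others in the source may bear on it.

In a functional assay on IGROV-1 cells (Homo sapiens) for cytotoxicity, read by sulforhodamine B assay, with a stated time of 48 h (a higher number here means a weaker inhibitor of growth, a lower number a stronger inhibitor of growth), three compounds have been measured:
Compound 1 `ClCc1ccccc1Cn1cnc2c(Cl)nc(Cl)nc21` gives 3310 nM.
Compound 2 `ClCc1ccccc1Cn1cnc2c(Cl)ncnc21` gives 8910 nM.
Compound 3 `ClCc1ccc(Cn2cnc3c(Cl)nc(Cl)nc32)cc1` gives 30200 nM.

Compound 2 holds the second highest number of the three; compound 1 sits nearest, with a lower number, and compound 3 furthest, with a higher one. The unmeasured compound 4 `Nc1nc(Cl)c2ncn(Cc3ccccc3CCl)c2n1` differs from compound 2 by amino in place of hydrogen on an aromatic carbon, on the carbon between two ring nitrogen atoms. For the measured compounds named here, only one measured step touches this position: a 2.7-fold higher number from compound 1 to compound 2 (0.43 log units; beyond the scatter), which shows that what sits there moves this assay beyond the scatter. Going by the values given here, no measured compound carries an amino group, so the direction for compound 4 is open. For compound 4 a small shift of a 1.3-fold lower number from compound 2 to compound 4 (0.10 log units; within the scatter) is estimated, with a value of 7000 nM expected to fall between 1800 nM and 27000 nM.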

Compound 4, concentration for total growth inhibition: > 100000 nM
Compound 4: a limit, no number; the forecaster's own chance of this, stated with the estimate: 5%; middle value at least 14-fold (1.15 log units) away from the limit.
By their numbers in this assay, from the lowest: compound 1; then compound 2; then compound 3. At a limit, above all of these: compound 4.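

In this assay compound 4 stands at a limit and not at a number: the limit of > 100000 nM in this assay, at which 1 of the 4 values shown sits.

The direction left open for amino at this carbon, between two ring nitrogen atoms, is now settled, with an at least 11-fold higher number from compound 2 to compound 4 (1.05 log units; beyond the scatter) and a large step, where the earlier exchange of chloro for hydrogen was modest. Set against chloro on the same carbon, amino gives an at least 30-fold higher number from compound 1 to compound 4 (1.48 log units; beyond the scatter) and a large step again.

As far as these compounds go, whether a methylamino or a methoxy group at this carbon would act as amino does remains open. So does whether amino would have the same effect on the core of compound 3.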